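Methoxy to hydroxy step from compound 2 to compound 3

A few compounds are considered here, and "the series" means these few. Any claim that something is new, unique, unknown or untested is made for them only; others in the source may bear on it.

Compound 1 `COc1ccc2c(c1)nc(/C=C/C(=O)/C=C/c1ccc(O)c(OC)c1)n2C`: 3800 nM
Compound 2 `COc1ccc2c(c1)nc(/C=C/C(=O)/C=C/c1ccc(OC)c(O)c1)n2C`: 4200 nM

In a functional assay on HepG2 cells (Homo sapiens) for cytotoxicity, read by MTT assay, with a stated time of 48 h (on this read-out lower numbers stand for stronger inhibition and higher numbers for weaker inhibition), the two measured compounds stand level, with a 1.1-fold higher number from compound 1 to compound 2 (0.04 log units; within the scatter) as the only gap, so compound 2 holds no distinct place in the series. Compound 3 `COc1ccc(/C=C/C(=O)/C=C/c2nc3cc(O)ccc3n2C)cc1O` keeps the 3-hydroxy-4-methoxyphenyl group of compound 2 and carries one change, methoxy to hydroxy (hydrogen in place of methyl on an oxygen on an aromatic ring), with hydrogen in place of methyl on an oxygen on an aromatic ring. Going by the values given here, no measured step covers this change. Among the compounds with values here, the one step available, a 1.1-fold higher number from compound 1 to compound 2 (0.04 log units; within the scatter), exchanges 4-hydroxy-3-methoxyphenyl for 3-hydroxy-4-methoxyphenyl, so it is only weak guidance. The estimate means a 1.1-fold higher number from compound 2 to compound 3 (0.03 log units; within the scatter) and no step beyond the scatter is expected in this assay, with no firm direction. Compound 3 is expected at 4500 nM, with an estimated range from 1800 nM to 11000 nM for the measurement.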

Compound 3, half-maximal inhibitory concentration: 3700 nM
Compound 3: the middle estimate sits 1.2-fold (0.09 log units) above what was measured; measured number inside the range.
By their numbers in this assay, from the lowest: compounds 3, 1 and 2 (each within the scatter of the next).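

Methoxy to hydroxy on the shared core, a place the earlier step between the two phenyl patterns left untouched, gives a 1.1-fold lower number from compound 2 to compound 3 (0.06 log units; within the scatter) in this assay. This position therefore accepts hydrogen in place of methyl on the oxygen without a step beyond the scatter, and the two changes seen so far, one on the phenyl group and one on the core, both leave the number level. Nothing available speaks to why this change leaves the read-out flat.

On these data alone, all three compounds carry only methoxy or hydroxy at these places, so it stays open whether a longer chain ether on that oxygen, or an amine or a carboxylic acid in place of the hydroxy, would move the number in this assay at all. Also open, as far as these compounds go, is how the core hydroxy behaves alongside the 4-hydroxy-3-methoxyphenyl group.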